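Swapping One Ring on a Compound Reported as Not Toxic

The compounds below may be only part of what the source reports. "The series", "measured", "known", "first", "only" and "open" are said of these compounds alone.

In an ADME assay on HEK-293T cells (Homo sapiens) for inhibition, read by CCK-8 assay, with a stated time of 48 h, tested at 20 uM (on this read-out higher numbers stand for more inhibition of growth at the one concentration tested and lower numbers for less inhibition of growth), compound 1 `Cc1ccc(S(=O)(=O)Oc2ccccc2/C=C(\C#N)C(=O)Nc2nnc(C)s2)cc1` gives 35% and compound 2 `COc1ccc(S(=O)(=O)Oc2ccccc2/C=C(\C#N)C(=O)Nc2nnc(-c3cccs3)s2)cc1` gives 40% as values within the scatter of each other. Compound 3 `COc1ccc(-c2nnc(NC(=O)/C(C#N)=C/c3cccc(OS(=O)(=O)c4ccc(C)cc4)c3)s2)cc1` has no single number and stands only as "not toxic" (no number reported) in the report. Compound 4 `Cc1ccc(S(=O)(=O)Oc2cccc(/C=C(\C#N)C(=O)Nc3nnc(-c4cccs4)s3)c2)cc1` carries thiophen-2-yl in place of 4-methoxyphenyl on an aromatic carbon and has not yet been measured. Among the compounds with values here, no measured step shows what this swap does. Compound 2 also carries thiophen-2-yl and gives 40% here, so a small step toward more inhibition is expected in this assay for the new compound. For compound 4 the estimated value is 20% with 5% to 42% as the expected range.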

Compound 4, percent growth inhibition at one concentration: 43%
Estimate against measurement, compound 4: 23 percentage points below; measured number outside the range, above it.
By their numbers in this assay, from the lowest: compounds 1, 2 and 4 (each within the scatter of the next).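

Compound 3 is reported only as "not toxic", without a number, so no step can be read to compound 4 at 43%. What swapping 4-methoxyphenyl for thiophen-2-yl does stays open, and no evidence here offers a reason for this result.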